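The source may hold more compounds than are shown below. What is called first, only, known or untested is meant among the compounds shown, and "the series" means these compounds.

Within the data shown here, compound 2 `COc1cc(Cl)cc(-c2nn(-c3cccc(NC(=O)Nc4ccc(Cl)c(C(F)(F)F)c4)c3)cc2-c2ccncc2)c1` is one of three compounds measured in a functional assay on DU-145 cells (Homo sapiens) for inhibition, read by sulforhodamine B assay, with a stated time of 48 h, tested at 0.01 uM (on this read-out higher numbers stand for a weaker effect at the one concentration tested and lower numbers for a stronger effect), and in it compound 2 gives 103%. Compound 1 `O=C(Nc1cccc(-n2cc(-c3ccncc3)c(-c3cc(O)cc(Cl)c3)n2)c1)Nc1ccc(Cl)c(C(F)(F)F)c1` gives 103%, and compound 3 `COc1cc(Cl)cc(-c2nn(-c3cccc(NC(=O)Nc4cc(C(F)(F)F)cc(C(F)(F)F)c4)c3)cc2-c2ccncc2)c1` gives 104%; the three numbers lie within the scatter of one another, with compound 2 level with compound 1. Compound 4 `COc1cc(Cl)cc(-c2nn(-c3cccc(NC(=O)c4cccc(C(F)(F)F)c4)c3)cc2-c2ccncc2)c1` differs from compound 2 by 3-(trifluoromethyl)phenyl in place of (4-chloro-3-(trifluoromethyl)phenyl)amino on a carbonyl carbon. Among the measured compounds shown here, the one measured step, no change at the digits printed from compound 1 to compound 2 (within the scatter), concerns a methyl in place of hydrogen on an oxygen on an aromatic ring and leaves the carbonyl carbon untouched, so no measured step speaks directly to this change. Since all three numbers agree, the step of a number 1 percentage points lower from compound 2 to compound 4 (within the scatter) is expected to be none beyond the scatter. Compound 4 is therefore estimated at 102%, within a range from 90% to 112%.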

Compound 4, a percentage reported as activity, at one concentration (the size of the read-out at that concentration, not a potency): 109%
Estimate against measurement, compound 4: 7 percentage points below; low and high end bracket the measured number.
By their numbers in this assay, from the lowest: compounds 1, 2, 3 and 4 (each within the scatter of the next).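

In this assay, the change on the carbonyl carbon gives a number 6 percentage points higher from compound 2 to compound 4 (within the scatter). Among these compounds, this is the first measured change at this place: (4-chloro-3-(trifluoromethyl)phenyl)amino, which carries a hydrogen-bond donor, gives way to 3-(trifluoromethyl)phenyl, which carries none, and the read-out stays within the scatter at the single concentration tested. Nothing available here bears on why this is so.

As far as these compounds go, with every number at this one concentration, it remains open whether the two groups would differ at higher concentrations. From the compounds shown here alone, how a carboxylic acid or a longer alkyl chain on the carbonyl carbon would read also remains open.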